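This account rests on a few compounds, and the source may have more. Where it says the series, first, only, none or still open, it means among the compounds named here.

Measured so far in a toxicity assay on HaCaT cells (Homo sapiens) for cytotoxicity, read by MTT assay; on this read-out lower numbers stand for stronger inhibition and higher numbers for weaker inhibition:
- Compound 1 `CC(C)c1ccc(-n2nc(-c3ccc(C(F)(F)F)cc3O)nc2-c2ccccc2O)cc1`: 51400 nM
- Compound 2 `Oc1cc(C(F)(F)F)ccc1-c1nc(-c2ccccc2O)n(-c2ccc(Br)cc2)n1`: 29600 nM

Going by the values given here, compound 2, at 29600 nM, cannot be told apart from compound 1, the only other measured compound, since the two lie within the scatter of repeated measurements. The next compound to be tested is compound 3 `Oc1cc(C(F)(F)F)ccc1-c1nc(-c2ccccc2O)n(-c2ccc(I)cc2)n1`, which keeps the whole of compound 2 except for one atom: iodo in place of bromo on an aromatic carbon, para to a large group (iodo in place of bromo on an aromatic carbon). Among the compounds with values here, no measured compound carries iodo, so the data hold no direct example of this swap. The nearest evidence is a single step, a 1.7-fold lower number from compound 1 to compound 2 (0.24 log units; within the scatter), which changed the group on that same aromatic carbon and stayed within the scatter. Within the data shown here, with only this small step to go on, no shift beyond the scatter is expected in this assay, and no direction can be favoured. The expected change is a 1.0-fold higher number from compound 2 to compound 3 (0.01 log units; within the scatter). For compound 3 the estimated value is 30000 nM, with an expected range from 15000 nM to 60000 nM.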

Compound 3, half-maximal inhibitory concentration: 32100 nM
The estimate for compound 3 lay 1.1-fold (0.03 log units) below the measured number, and the stated range covers the measured number.
By their numbers in this assay, from the lowest: compounds 2, 3 and 1 (each within the scatter of the next).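

In this assay, going by these compounds alone, iodo in place of bromo gives a 1.1-fold higher number from compound 2 to compound 3 (0.04 log units; within the scatter), a first direct comparison of two halogens on this aromatic carbon, and the two compounds cannot be told apart. Iodo in place of isopropyl gives a 1.6-fold lower number from compound 1 to compound 3 (0.20 log units; within the scatter), which also stays within the scatter, so isopropyl, bromo and iodo at this place, para to a large group, now all give numbers that cannot be separated from one another. No measurement available here explains why these three compounds cannot be separated.

The compounds shown leave open whether this carbon would keep the same numbers with a very different kind of group, such as an amine or a carboxylic acid, since the three groups seen here give no sign of what such a group would do. Whether the same picture would hold on a different core, or in any read-out other than this assay, also remains unanswered.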